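The compounds below may be only part of what the source reports. "The series", "measured", "known", "first", "only" and "open" are said of these compounds alone.

Measured so far:
- Compound 1 `Nc1ccccc1NC(=O)c1ccc(CNC(=O)c2n[nH]cc2NC(=O)c2c(F)cccc2Cl)cc1`: 3270 nM
- Compound 2 `Nc1ccccc1NC(=O)c1ccc(CNC(=O)c2n[nH]cc2NC(=O)c2ccccc2Cl)cc1`: 10500 nM
- Compound 3 `COc1ccccc1C(=O)Nc1c[nH]nc1C(=O)NCc1ccc(C(=O)Nc2ccccc2N)cc1`: 8130 nM

In a functional assay on HeLa cells (Homo sapiens) for inhibition, read by CCK-8 assay, with a stated time of 72 h (on this read-out higher numbers stand for weaker inhibition and lower numbers for stronger inhibition), the gap to compound 3 is small on one side, a 1.3-fold lower number from compound 2 to compound 3 (0.11 log units; within the scatter), and larger on the other, a 2.5-fold higher number from compound 1 to compound 3 (0.40 log units; beyond the scatter). Compound 4 `Nc1ccccc1NC(=O)c1ccc(CNC(=O)c2n[nH]cc2NC(=O)c2c(F)cccc2F)cc1` keeps the shared core and swaps one group: 2,6-difluorophenyl in place of 2-methoxyphenyl on a carbonyl carbon. Within the data shown here, no measured compound carries this group. The closest guide is compound 1, with its 2-chloro-6-fluorophenyl group, and removing its fluoro gave a 3.2-fold higher number from compound 1 to compound 2 (0.51 log units; beyond the scatter). A modest move towards a lower number is therefore expected, similar in size to those steps. The expected step is a 1.8-fold lower number from compound 3 to compound 4 (0.26 log units; within the scatter). For compound 4 the estimated value is 4500 nM, within an expected range of 1800 nM to 10000 nM.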

Compound 4, half-maximal inhibitory concentration: 4480 nM
Compound 4: the middle estimate sits 1.0-fold (0.00 log units) above what was measured; low and high end bracket the measured number.
By their numbers in this assay, from the lowest: compounds 1, 4, 3 and 2 (each within the scatter of the next, the first and the last beyond it).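

In this assay, the 2,6-difluorophenyl group on this carbonyl carbon stays within the scatter of both the 2-methoxyphenyl group (a 1.8-fold lower number from compound 3 to compound 4 (0.26 log units; within the scatter)) and the 2-chloro-6-fluorophenyl group (a 1.4-fold higher number from compound 1 to compound 4 (0.14 log units; within the scatter)). Among these compounds, it clears the scatter only against the 2-chlorophenyl group (a 2.3-fold lower number from compound 2 to compound 4 (0.37 log units; beyond the scatter)), so a second halogen on this ring gave a lower number than the single chloro in both compound 1 and compound 4, while compound 3, with its single methoxy, sits within the scatter of both compound 2 and compound 4. No measurement here gives a reason for these steps. Still open, as far as these compounds go, is how a 2,6-dichlorophenyl or 2,6-dimethylphenyl group would read at this carbonyl carbon.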